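This account rests on a few compounds, and the source may have more. Where it says the series, first, only, none or still open, it means among the compounds named here.

Compound 2 `COc1cc(-c2ncnn2-c2cccc(N)c2)cc(OC)c1OC` belongs to a small set of compounds sharing one core that were tested in a functional assay on HeLa cells (Homo sapiens) for antiproliferative activity, read by MTT assay, with a stated time of 72 h; on this read-out lower numbers stand for stronger inhibition and higher numbers for weaker inhibition. In this assay compound 2 gives > 10000 nM, which is a limit of the assay rather than a number. Compound 1 `COc1ccccc1-c1ncnn1-c1cc(OC)c(OC)c(OC)c1` gives > 10000 nM in this assay, again a limit. Compound 3 `COc1cc(-n2ncnc2-c2cccc(F)c2)cc(OC)c1OC` gives > 10000 nM in this assay, also a limit. All of them therefore sit at the limit of > 10000 nM in this assay, at which 3 of the 3 values shown sit, so compound 2 stands at the same limit as every other measured compound, with no number to place it above or below them. Going by the values given here, the only measured step between compounds differing in one place, a step that the two limits leave unreadable from compound 1 to compound 3, has a size that the two limits leave unreadable. Compound 4 `COc1cc(-c2ncnn2-c2ccc(F)cc2)cc(OC)c1OC` is not yet measured and differs from compound 2 by 4-fluorophenyl in place of 3-aminophenyl on an aromatic nitrogen. Among the compounds with values here, no measured step bears directly on this change, and the one available step offers no readable size, so the expectation for compound 4 rests only on the limit shared by all three measured compounds. Compound 4 is therefore expected to remain near that limit, estimated at 15000 nM, within 4000 nM to 50000 nM. The step that the limit leaves unreadable from compound 2 to compound 4 is accordingly expected to be none beyond the scatter.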

Compound 4, half-maximal inhibitory concentration: > 10000 nM
Compound 4 gave a limit, no number; the forecaster's own chance of this, stated with the estimate: 75%; the middle value does not contradict the limit.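

Compound 2 and compound 4 both stand at one limit, so no new step can be read between them: the limit of > 10000 nM in this assay, at which 4 of the 4 values shown sit. None of the compounds shown gives a number in this assay, which leaves open whether any change on the shared core alters the read-out at all.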